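Swapping fluoro for bromo in a cytotoxicity test

A few compounds are considered here, and "the series" means these few. Any claim that something is new, unique, unknown or untested is made for them only; others in the source may bear on it.

Values measured so far in an ADME assay on HepG2 cells (Homo sapiens) for cytotoxicity, read by MTT assay, with a stated time of 48 h (on this read-out higher numbers stand for lower toxicity in this test and lower numbers for higher toxicity in this test), are these
- compound 1 `CC(=O)OC[C@H]1O[C@H](OC[C@@H](Cn2cc(CN(c3nc(-c4cccc([N+](=O)[O-])c4)no3)C3CCCCC3)nn2)OC(C)=O)C=C[C@@H]1OC(C)=O` gives > 200 ug/mL as a limit
- compound 2 `C#CCN(c1nc(-c2ccc(Cl)cc2)no1)C1CCCCC1` gives 41.3 ug/mL as a number
- compound 3 `C#CCN(c1nc(-c2ccc(F)cc2)no1)C1CCCCC1` gives 41.1 ug/mL as a number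

Compound 1 stands at the limit of > 200 ug/mL in this assay, at which 1 of the 3 values shown sits, and that entry is a limit, not a number. Within the data shown here, compound 3 gives 41.1 ug/mL and compound 2 gives 41.3 ug/mL so the two lie within the scatter of each other, and they are the only true numbers available.

Compound 4 `C#CCN(c1nc(-c2ccc(Br)cc2)no1)C1CCCCC1` has not yet been measured in this assay and differs from compound 3 in one group. The change is bromo in place of fluoro on an aromatic carbon and in words it is bromo in place of fluoro on an aromatic carbon, or 4-fluorophenyl to 4-bromophenyl.

Among the measured compounds shown here, one measured step bears on this, fluoro in place of chloro on an aromatic carbon, and it came to a 1.0-fold lower number from compound 2 to compound 3 (0.00 log units; within the scatter) in this test. A single step is thin support, but it points to no shift, so the expected size is a 1.0-fold lower number from compound 3 to compound 4 (0.01 log units; within the scatter) and this estimate means nothing beyond the scatter. Compound 4 is therefore expected at 40 ug/mL in this assay with an estimated range from 22 ug/mL to 75 ug/mL around that figure.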

Compound 4, half-maximal cytotoxic concentration: 102 ug/mL
For compound 4 the middle estimate is 2.6-fold (0.41 log units) below the measured one; measured number above the stated range.
By their numbers in this assay, from the lowest: compounds 3 and 2 (each within the scatter of the next); then compound 4. At a limit, above all of these: compound 1.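

In this assay the halogen on this aromatic carbon, para to a large group, proves not to be freely interchangeable: chloro and fluoro could not be told apart, yet bromo gives a 2.5-fold higher number from compound 3 to compound 4 (0.39 log units; beyond the scatter) and, against chloro, a 2.5-fold higher number from compound 2 to compound 4 (0.39 log units; beyond the scatter) on the same scaffold. Both steps are modest but point the same way, so in this test compound 4 is less toxic than compound 2 and compound 3, and the result depends on which halogen is present rather than on the presence of a halogen alone. Nothing measured for these compounds explains why bromo separates from the other two halogens.

Three halogens at one position cannot show whether this step is particular to bromo or would recur with iodo, or with a non-halogen group such as methyl or an amine in the same place. From the compounds shown here alone, it also remains open whether swapping chloro or fluoro for bromo would give a step of similar size on a different core.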